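A few compounds are considered here, and "the series" means these few. Any claim that something is new, unique, unknown or untested is made for them only; others in the source may bear on it.

Of the compounds shown here, three built on the same core have been tested in a functional assay (aorta) with Oryctolagus cuniculus as the target; a higher number here means a weaker inhibitor, a lower number a stronger inhibitor. Compound 1 `CO/C(O)=C1\C(C)=NC(C)=C(C(=O)OCCCN2C(=O)c3ccccc3S2(=O)=O)C1c1cccc([N+](=O)[O-])c1` gives 2.6 nM in this assay. Compound 2 `CCO/C(O)=C1\C(C)=NC(C)=C(C(=O)OCCCN2C(=O)c3ccccc3S2(=O)=O)C1c1cccc([N+](=O)[O-])c1` gives 1.9 nM in this assay. Compound 3 `CO/C(O)=C1\C(C)=NC(C)=C(C(=O)OCCCN2C(=O)c3ccccc3S2(=O)=O)C1c1ccccc1[N+](=O)[O-]` gives 1.5 nM in this assay. Compound 3 carries the lowest of the three numbers, yet its gaps to compound 2 and to compound 1 both sit within the scatter, so the three cannot be told apart on this evidence.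

Compound 4 `CCO/C(O)=C1\C(C)=NC(C)=C(C(=O)OCCCN2C(=O)c3ccccc3S2(=O)=O)C1c1ccccc1[N+](=O)[O-]` differs from compound 3 in one place: methyl in place of hydrogen on a saturated chain carbon bound to an oxygen on an unsaturated carbon. The same change has been seen once before, where a 1.4-fold lower number from compound 1 to compound 2 (0.14 log units; within the scatter). The other measured step, where a 1.7-fold lower number from compound 1 to compound 3 (0.24 log units; within the scatter), concerns the nitrophenyl group and only fixes the starting point of compound 3. Among the measured compounds shown here, with the one matching step inside the scatter, no shift beyond the scatter is expected; the expected step is a 1.2-fold lower number from compound 3 to compound 4 (0.06 log units; within the scatter). Compound 4 is therefore estimated at 1.3 nM, within a range from 0.5 nM to 3.5 nM.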

Compound 4, half-maximal inhibitory concentration: 2.6 nM
Beside the measured number, compound 4's estimate is 2.0-fold (0.30 log units) below it; the measured number falls inside the stated range.
By their numbers in this assay, from the lowest: compounds 3, 2, 1 and 4 (each within the scatter of the next).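

In this assay, the methoxy to ethoxy change on the 2-nitrophenyl compounds gives a 1.7-fold higher number from compound 3 to compound 4 (0.24 log units; within the scatter), so this position now has a reading on two cores, and neither reading goes beyond the scatter. The two readings point in opposite directions, but even their gap cannot be told from noise: the same change on two cores in this assay, a 1.4-fold lower number (0.14 log units; within the scatter) from compound 1 to compound 2 and a 1.7-fold higher number (0.24 log units; within the scatter) from compound 3 to compound 4, 2.4-fold (0.38 log units) apart, within the scatter of two such steps. Likewise, 2-nitrophenyl in place of 3-nitrophenyl, now also read with ethoxy, gives a 1.4-fold higher number from compound 2 to compound 4 (0.14 log units; within the scatter), and this change also shows no consistent shift: the same change on two cores in this assay, a 1.7-fold lower number (0.24 log units; within the scatter) from compound 1 to compound 3 and a 1.4-fold higher number (0.14 log units; within the scatter) from compound 2 to compound 4, 2.4-fold (0.38 log units) apart, within the scatter of two such steps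

The compounds shown cover only methoxy and ethoxy at this position, so how a longer chain such as butoxy, or an amine, would read there remains open. Whether any group at this position can move the number beyond the scatter is also unsettled.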